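Replacing the methoxypyridine of compound 3 with a pyrazole

The compounds below may be only part of what the source reports. "The series", "measured", "known", "first", "only" and "open" are said of these compounds alone.

Of the compounds shown here, three sharing one core have been measured in a functional assay on MDA-MB-436 cells (Homo sapiens) for antiproliferative activity, read by MTT assay, with a stated time of 48 h; on this read-out lower numbers stand for stronger inhibition and higher numbers for weaker inhibition. Compound 1 `C=CS(=O)(=O)N1CCN(c2ncnc3sc(-c4ccc(C(F)(F)F)cc4)cc23)CC1` gives 7080 nM, compound 2 `C=CS(=O)(=O)N1CCN(c2ncnc3sc(-c4ccnc(Cl)c4)cc23)CC1` gives 30100 nM, and compound 3 `C=CS(=O)(=O)N1CCN(c2ncnc3sc(-c4ccc(OC)nc4)cc23)CC1` gives 11900 nM. Two steps fix the standing of compound 3. The first is a 1.7-fold higher number from compound 1 to compound 3 (0.23 log units; within the scatter), so it cannot be told apart from compound 1. The second is a 2.5-fold lower number from compound 2 to compound 3 (0.40 log units; beyond the scatter).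

Compound 4 `C=CS(=O)(=O)N1CCN(c2ncnc3sc(-c4cn(C)nc4C(F)(F)F)cc23)CC1` has not yet been measured. It carries 1-methyl-3-(trifluoromethyl)-1H-pyrazol-4-yl in place of 6-methoxypyridin-3-yl, on the aromatic carbon next to the ring sulfur: 1-methyl-3-(trifluoromethyl)-1H-pyrazol-4-yl in place of 6-methoxypyridin-3-yl on an aromatic carbon.

All three measured steps changed this same place, so all three bear on the new change. Besides the two above, there is a 4.3-fold higher number from compound 1 to compound 2 (0.63 log units; beyond the scatter). Each is modest or within the scatter. Within the data shown here, compound 1, at 7080 nM, also carries a trifluoromethyl group, but no measured compound has a five-membered aromatic ring here, so the data favour no direction. In this assay, the expected outcome is a 1.1-fold lower number from compound 3 to compound 4 (0.03 log units; within the scatter), which means no step beyond the scatter. Compound 4 is estimated at 11000 nM, with an expected range from 4500 nM to 28000 nM.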

Compound 4, half-maximal inhibitory concentration: 15100 nM
Compound 4: the middle estimate sits 1.4-fold (0.14 log units) below what was measured; the range from low to high includes it.
By their numbers in this assay, from the lowest: compounds 1, 3, 4 and 2 (each within the scatter of the next, the first and the last beyond it).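

In this assay, a five-membered aromatic ring with 2 hetero atoms proves to be accommodated on the aromatic carbon next to the ring sulfur: a 1.3-fold higher number from compound 3 to compound 4 (0.10 log units; within the scatter), so the 1-methyl-3-(trifluoromethyl)-1H-pyrazol-4-yl group cannot be told apart from the 6-methoxypyridin-3-yl group, and a 2.0-fold lower number from compound 2 to compound 4 (0.30 log units; within the scatter) also leaves compound 4 unresolved from the 2-chloropyridin-4-yl analogue. Only the comparison with the 4-(trifluoromethyl)phenyl analogue passes the scatter, with a 2.1-fold higher number from compound 1 to compound 4 (0.33 log units; beyond the scatter), and that step is modest even though both groups carry a trifluoromethyl group, so sharing that group does not make the two compounds match. Nothing given here accounts for any of these steps.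

The compounds shown leave open how an open-chain amine or a carboxylic acid would behave on this carbon, since every group placed there so far is an aromatic ring. They also leave open how far the numbers depend on the vinyl sulfonyl group, which all four compounds share, and whether an acrylamide in its place would give similar values.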